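The source may hold more compounds than are shown below. What is called first, only, known or untested is meant among the compounds shown, and "the series" means these compounds.

Compound 1 `Cc1cc(N2CC[C@@H](C)[C@@H](N(C)c3ncnc4[nH]ccc34)C2)n2nc(SCc3ccc(Cl)cc3)nc2n1` is the starting point. In a functional assay on BGC-823 cells (Homo sapiens) for inhibition, read by MTT assay, with a stated time of 72 h (a higher number here means a weaker inhibitor, a lower number a stronger inhibitor), compound 1 gives 26300 nM, the second highest of the three numbers measured. Compound 3 `Cc1cc(N2CC[C@@H](C)[C@@H](N(C)c3ncnc4[nH]ccc34)C2)n2nc(SCC3CCCCC3)nc2n1` gives 16300 nM, and the step of a 1.6-fold lower number from compound 1 to compound 3 (0.21 log units; within the scatter) keeps the two within the usual scatter. Compound 2 `Cc1cc(N2CC[C@@H](C)[C@@H](N(C)c3ncnc4[nH]ccc34)C2)n2nc(SCc3ccccc3Br)nc2n1` gives 81100 nM, the highest number, and the step of a 3.1-fold higher number from compound 1 to compound 2 (0.49 log units; beyond the scatter) is a modest rise beyond the scatter; the step of a 5.0-fold lower number from compound 2 to compound 3 (0.70 log units; beyond the scatter) is likewise modest.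

The new compound 4 `Cc1cc(N2CC[C@@H](C)[C@@H](N(C)c3ncnc4[nH]ccc34)C2)n2nc(SCc3ccc(Br)cc3)nc2n1` differs from compound 1 only in one place: bromo in place of chloro on an aromatic carbon. Cut one bond further out, the (4-chlorobenzyl)sulfanyl group becomes a (4-bromobenzyl)sulfanyl group. Within the data shown here, none of the measured steps swaps one halogen for another at the same place; the step from compound 1 to compound 2 moves the halogen to a different position as well as changing it, and the step to compound 3 removes the aromatic ring entirely. Among the measured compounds shown here, no measured step therefore bears directly on this change, and no step beyond the scatter is expected.

For compound 4 the estimated value in this assay is 26000 nM, with a range from 12000 nM to 55000 nM. This estimate means an expected 1.0-fold lower number from compound 1 to compound 4 (0.00 log units; within the scatter).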

Compound 4, half-maximal inhibitory concentration: 28000 nM
Estimate against measurement, compound 4: 1.1-fold (0.03 log units) below, and the stated range covers the measured number.
By their numbers in this assay, from the lowest: compounds 3, 1 and 4 (each within the scatter of the next); then compound 2.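

In this assay, bromo and chloro on the aromatic carbon para to a large group cannot be told apart (a 1.1-fold higher number from compound 1 to compound 4 (0.03 log units; within the scatter)), and the 4-bromobenzyl group cannot be told from the cyclohexyl group of compound 3 (a 1.7-fold higher number from compound 3 to compound 4 (0.23 log units; within the scatter)). The pair of compound 2 and compound 4 carries the same halogen, so it isolates where the bromo sits on the ring, which the earlier step between compound 1 and compound 2 could not do: the 4-bromophenyl group gives a modest gain over the 2-bromophenyl group (a 2.9-fold lower number from compound 2 to compound 4 (0.46 log units; beyond the scatter)). Nothing given here explains these results.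

Still open, on these data alone, is whether a fluoro or methoxy group, or an amine or carboxylic acid, would be tolerated at this place on the ring. Also open, as far as these compounds go, is how a longer chain between the sulfur and the ring would read.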